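Series notes: amide to hydrazide on the shared core

The source may report more compounds than this note shows. Statements on the series, on what has been measured and on what is new or still open speak of the compounds shown alone.

Measured so far:
compound 1 `N#Cc1ccc(-c2cc(-c3ccc(C(N)=O)cc3)cc(-c3ccco3)n2)cc1` — 10000 nM
compound 2 `NC(=O)c1ccc(-c2cc(-c3ccc(-c4cnco4)cc3)nc(-c3ccco3)c2)cc1` — 15000 nM

In a physicochemical assay for solubility, at pH 6 (on this read-out lower numbers stand for lower solubility and higher numbers for higher solubility), compound 1 gives 10000 nM, the lower of the two numbers; compound 2 gives 15000 nM. Among the measured compounds shown here, the one step between them, a 1.5-fold higher number from compound 1 to compound 2 (0.18 log units; within the scatter), changes the cyano group and falls within the scatter.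

Compound 3 `N#Cc1ccc(-c2cc(-c3ccc(C(=O)NN)cc3)cc(-c3ccco3)n2)cc1` has not yet been measured in this assay. It differs from compound 1 by amino in place of hydrogen on an amide-type nitrogen; the same difference, cut one bond further out, reads carbamoyl to aminocarbamoyl. For the measured compounds named here, no measured step touches the amide nitrogen, so no step among the two compounds bears on this change; the only step available, a 1.5-fold higher number from compound 1 to compound 2 (0.18 log units; within the scatter), concerns a different position and is within the scatter. With nothing to anchor a shift, the expectation for compound 3 in this assay is a step of about a 1.2-fold higher number from compound 1 to compound 3 (0.08 log units; within the scatter), that is, none beyond the scatter. Compound 3 is therefore estimated at 12000 nM, with a range from 5000 nM to 30000 nM.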

Compound 3, solubility: 500000 nM
For compound 3 the middle estimate is 42-fold (1.62 log units) below the measured one, outside the stated range (above it).
By their numbers in this assay, from the lowest: compounds 1 and 2 (each within the scatter of the next); then compound 3.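

In this assay, amino in place of hydrogen on an amide-type nitrogen gives a 50-fold higher number from compound 1 to compound 3 (1.70 log units; beyond the scatter), a large step beyond the scatter, so this position responds strongly to the addition of a single heavy atom. Among the compounds shown here, the only earlier step, a 1.5-fold higher number from compound 1 to compound 2 (0.18 log units; within the scatter), lay at the cyano group and stayed within the scatter, so the amide-type nitrogen is the first place in this small set where one change moves the read-out beyond it. Nothing available here accounts for the size of this step.

The compounds shown leave open whether the step is specific to amino or would also follow from a hydroxyl group, a methyl group or a longer chain such as 2-aminoethyl on the same nitrogen. They also leave open whether the same change carries a comparable step when 1,3-oxazol-5-yl stands in place of cyano.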